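A few compounds are considered here, and "the series" means these few. Any claim that something is new, unique, unknown or untested is made for them only; others in the source may bear on it.

In a functional assay on Jurkat cells (Homo sapiens) (on this read-out higher numbers stand for weaker inhibition and lower numbers for stronger inhibition), compound 1 (`CC(C)[C@H](NC(=O)COc1cccc2ccccc12)C(=O)N[C@@H](CC(=O)O)C(=O)COc1cccc(C(F)(F)F)c1`) gives > 100000 nM as a limit, not a number. Compound 2 (`CC(C)[C@H](NC(=O)COc1cccc2ccccc12)C(=O)N[C@@H](CC(=O)O)C(=O)COc1ccc(F)c(F)c1`) gives > 100000 nM as a limit too. Compound 3 (`CC(C)[C@H](NC(=O)COc1cccc2ccccc12)C(=O)N[C@@H](CC(=O)O)C(=O)COc1cc(F)cc(F)c1`) likewise gives > 100000 nM as a limit, so it has no number of its own and stands with the other two (the limit of > 100000 nM in this assay, at which 3 of the 3 values shown sit). Compound 4 (`CC(C)[C@H](NC(=O)COc1cccc2ccccc12)C(=O)N[C@@H](CC(=O)O)C(=O)COc1c(F)cc(F)cc1F`) carries 2,4,6-trifluorophenyl in place of 3,5-difluorophenyl on an oxygen on a saturated carbon. The nearest measured changes (a step that the two limits leave unreadable from compound 2 to compound 3) and (a step that the two limits leave unreadable from compound 1 to compound 3) offer no size to carry over. Any readable change in this assay would therefore have to be toward stronger inhibition, and the range stays wide. The estimate for compound 4 is 60000 nM as a middle value, with 5000 nM to 150000 nM as the expected range. The expected change is an at least 1.6-fold lower number from compound 3 to compound 4 (0.22 log units; that floor lies within the scatter) by this estimate.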

Compound 4, half-maximal inhibitory concentration: 6840 nM
For compound 4 the middle estimate is 8.8-fold (0.94 log units) above the measured one, and the stated range covers the measured number.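

In this assay, the group on the oxygen on a saturated carbon proves able to shift the read-out: 2,4,6-trifluorophenyl gives an at least 14-fold lower number from compound 3 to compound 4 (1.16 log units; beyond the scatter) and an at least 14-fold lower number from compound 2 to compound 4 (1.16 log units; beyond the scatter) as well as an at least 14-fold lower number from compound 1 to compound 4 (1.16 log units; beyond the scatter) in the same place. The steps among compound 1, compound 2 and compound 3 cannot be read. Compound 4 alone stands clear of the limit that holds the other three: the limit of > 100000 nM in this assay, at which 3 of the 4 values shown sit. Still open, going by these compounds, is how pentafluorophenyl or plain phenyl would read in that place, and whether the gain survives replacing the carboxylic acid with a methyl ester.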